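Replacing the benzyloxy group at the saturated ring carbon

The source may report more compounds than this note shows. Statements on the series, on what has been measured and on what is new or still open speak of the compounds shown alone.

Among the measured compounds shown here, compound 2 `Cc1nn(-c2ncnc3nc[nH]c23)c2c1C(OCc1ccccc1Cl)CC(=O)N2` holds the lowest of the two numbers so far: in a functional assay on HEK293 cells for agonist activity at G-protein coupled receptor 39 (Homo sapiens), read by scintillation proximity assay and inositol phosphate accumulation, with a stated time of 75 min (on this read-out higher numbers stand for an effect only at larger amounts of compound and lower numbers for an effect already at smaller amounts), compound 2 gives 47 nM, whereas compound 1 `Cc1nn(-c2ncnc3nc[nH]c23)c2c1C(C(=O)N(C)c1ccccc1)CC(=O)N2` gives 5220 nM. For the measured compounds named here, the only measured step, a 110-fold lower number from compound 1 to compound 2 (2.05 log units; beyond the scatter), shows that the group on this saturated ring carbon governs the read-out strongly. Compound 3 `Cc1nn(-c2ncnc3nc[nH]c23)c2c1C(c1ccc(F)cc1Cl)CC(=O)N2` differs from compound 2 by 2-chloro-4-fluorophenyl in place of (2-chlorobenzyl)oxy on a saturated ring carbon, so the linking oxygen and methylene are gone and the aromatic ring sits directly on the carbon. Going by the values given here, no measured pair tests this shortening, and the large step seen from compound 1 gives no direction for it, only a warning that changes here can be large. Compound 3 is therefore expected to lose some ground against compound 2, with wide uncertainty, a 4.3-fold higher number from compound 2 to compound 3 (0.63 log units; beyond the scatter). The estimate for compound 3 is 200 nM, within 20 nM to 2000 nM.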

Compound 3, half-maximal effective concentration: 280 nM
Beside the measured number, compound 3's estimate is 1.4-fold (0.15 log units) below it; the range from low to high includes it.
By their numbers in this assay, from the lowest: compound 2; then compound 3; then compound 1.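

In this assay removing the linking oxygen and methylene gave a 6.0-fold higher number from compound 2 to compound 3 (0.78 log units; beyond the scatter) and this modest step shows that the aromatic ring can sit directly on the saturated ring carbon at a limited cost, though not without one. Replacing the methyl(phenyl)carbamoyl group with the same ring gave a 19-fold lower number from compound 1 to compound 3 (1.27 log units; beyond the scatter) so two different attachments of a chlorinated aromatic ring, with and without the linking atoms, both give lower numbers than the carbamoyl group. Nothing measured here accounts for either step.

The change from compound 2 to compound 3 also adds a fluorine, so the share of the fluorine and the share of the lost linking atoms in the step stay unseparated. From the compounds shown here alone, how a longer chain, such as a 2-(2-chlorophenyl)ethyl group, or an amine would read out on this carbon remains open.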